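Fluoro to methyl on the benzyl arm of compound 1

This account rests on a few compounds, and the source may have more. Where it says the series, first, only, none or still open, it means among the compounds named here.

Measured compounds in a functional assay (QGY7701 cells, Homo sapiens) for inhibition, read by MTT assay, with a stated time of 48 h; on this read-out higher numbers stand for weaker inhibition and lower numbers for stronger inhibition:
compound 1, `O=C(/C=C/c1coc2cc(O)ccc2c1=O)NCc1ccc(F)cc1`, > 100000 nM
compound 2, `COc1ccc2c(=O)c(/C=C/C(=O)Nc3ccc(C)cc3)coc2c1`, 39300 nM
compound 3, `COc1ccc2c(=O)c(/C=C/C(=O)NCc3cccc(F)c3)coc2c1`, 28600 nM

Compound 1 carries a hydroxyl on the shared core and a 4-fluorobenzyl on the amide nitrogen. Its result in this assay is a limit, not a number: compound 1 shows > 100000 nM, so only the edge of the assay is known for it, as marked by the limit of > 100000 nM in this assay, at which 1 of the 3 values shown sits. Compounds 2 and 3 carry a methoxy on the core instead, and their values are numbers; the step of a 1.4-fold lower number from compound 2 to compound 3 (0.14 log units; within the scatter) is within the scatter.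

Compound 4, `Cc1ccc(CNC(=O)/C=C/c2coc3cc(O)ccc3c2=O)cc1`, differs from compound 1 in one place: methyl in place of fluoro on an aromatic carbon. Fluoro leaves and methyl enters; no ring, no donor and no acceptor changes. Going by the values given here, no measured step covers this exchange. Among the compounds with values here, the only measured step, from a 4-methylphenyl to a 3-fluorobenzyl, stayed within the scatter, and compound 1 itself sits at the limit. The expected step of a number no higher from compound 1 to compound 4 (the limit leaves the size open) is therefore none beyond the scatter.

Compound 4 is estimated at 100000 nM, with a range from 40000 nM to 300000 nM, most likely again reported only as a limit.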

Compound 4, half-maximal inhibitory concentration: 24900 nM
Compound 4: middle estimate off by 4.0-fold (0.60 log units), on the high side; measured number outside the range, below it.
By their numbers in this assay, from the lowest: compounds 4, 3 and 2 (each within the scatter of the next). At a limit, above all of these: compound 1.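

In this assay, methyl in place of fluoro gives an at least 4.0-fold lower number from compound 1 to compound 4 (0.60 log units; beyond the scatter), the first step among the compounds shown that lies beyond the scatter. Going by these compounds alone, the earlier step between compound 2 and compound 3 showed no such change, so this is the first sign that the read-out responds to a change on an aromatic carbon para to a large group, even though no ring, donor or acceptor changes in the exchange. The true size of the step stays open, because compound 1 is known only through a limit: the limit of > 100000 nM in this assay, at which 1 of the 4 values shown sits.

The compounds shown leave open whether chloro, trifluoromethyl or an amine in that same place would give a number closer to that of compound 4 or would stay at a limit like compound 1, and so whether methyl itself matters or the fluoro is simply a poor fit to this read-out. They also leave open whether the same exchange of fluoro for methyl would give a step of similar size on a core carrying methoxy in place of hydroxyl.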